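Stilbene-type series on HL-60: aryl swap at the styryl end

The source may report more compounds than this note shows. Statements on the series, on what has been measured and on what is new or still open speak of the compounds shown alone.

Measured so far, in a functional assay on HL-60 cells (Homo sapiens) for cytotoxicity; a higher number here means a weaker inhibitor, a lower number a stronger inhibitor:
- compound 1 `CC1(C)CCC(C)(C)c2cc(/C=C/c3cccc(N)c3)ccc21`: 20000 nM
- compound 2 `COc1ccc(/C=C(\C)c2ccc3c(c2)C(C)(C)CCC3(C)C)cc1N`: 20000 nM
- compound 3 `CC1(C)CCC(C)(C)c2cc(/C=C\c3ccc(N)cc3)ccc21`: 18000 nM

Compound 1 stands level with compound 2 at the digits given, the two together the highest numbers of the three; compound 3 differs from compound 1 by an amount within the scatter. All three numbers sit in the same weak region, and no comparison among them goes beyond the scatter.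

Compound 4 `COc1ccc(/C=C/c2ccc3c(c2)C(C)(C)CCC3(C)C)cc1` is the next candidate, differing from compound 1 by 4-methoxyphenyl in place of 3-aminophenyl on a double-bonded chain carbon bound to a double-bonded chain carbon. Among the compounds with values here, no measured pair shows this change, so nothing here tells its direction. Given how close compound 1, compound 2 and compound 3 lie, a step from compound 1 to compound 4 beyond the scatter is not expected; the estimated step is no change at the digits printed from compound 1 to compound 4 (within the scatter). Compound 4 is expected near 20000 nM, within 7000 nM to 60000 nM.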

Compound 4, half-maximal inhibitory concentration: 50000 nM
Estimate against measurement, compound 4: 2.5-fold (0.40 log units) below; low and high end bracket the measured number.
By their numbers in this assay, from the lowest: compounds 3, 1 and 2 (each within the scatter of the next); then compound 4.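

In this assay, the series gives its first step beyond the scatter, a 2.5-fold higher number from compound 1 to compound 4 (0.40 log units; beyond the scatter), so the aryl group on a double-bonded chain carbon bound to a double-bonded chain carbon can shift the number, though only modestly and towards weaker inhibition. The swap to 4-methoxyphenyl changes both the substituent and its ring position and leaves no hydrogen-bond donor, and this single step cannot separate those differences. No available evidence bears on the reason for the shift. Open, from the compounds shown here alone, is which of those differences carries the step, and whether a carboxylic acid on this aryl ring would bring the number out of the weak region.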